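Chloro for hydrogen on the pendant phenyl of compound 3

The source may hold more compounds than are shown below. What is called first, only, known or untested is meant among the compounds shown, and "the series" means these compounds.

Within the data shown here, compound 1 `CCO/C=C(\C#N)C(=O)N/N=C(\C)c1ccc(NS(=O)(=O)c2ccc(Cl)cc2)cc1` gives 16800 nM in a functional assay on HepG2 cells (Homo sapiens) for cytotoxicity, read by sulforhodamine B assay, with a stated time of 48 h; a lower number here means a stronger inhibitor, a higher number a weaker inhibitor; compound 2 `CSC(SC)=C(C#N)C(=O)N/N=C(\C)c1ccc(NS(=O)(=O)c2ccc(Cl)cc2)cc1` gives 19400 nM, the single measured step being a 1.2-fold higher number from compound 1 to compound 2 (0.06 log units; within the scatter). Compound 3 `CCOC(=O)c1c(-c2ccccc2)c(C#N)c(=O)n(/N=C(\C)c2ccc(NS(=O)(=O)c3ccc(Cl)cc3)cc2)c1N` gives 16800 nM, level with compound 1 at the digits shown, while compound 2 stands within the scatter of both. Compound 4 `CCOC(=O)c1c(-c2ccc(Cl)cc2)c(C#N)c(=O)n(/N=C(\C)c2ccc(NS(=O)(=O)c3ccc(Cl)cc3)cc2)c1N` carries chloro in place of hydrogen on an aromatic carbon, read one bond further out as phenyl to 4-chlorophenyl. Among the measured compounds shown here, no measured step touches this ring; the only step known concerns a different part of the shared core and lies within the scatter itself, so no change beyond the scatter is expected for compound 4, estimated as a 1.1-fold lower number from compound 3 to compound 4 (0.02 log units; within the scatter). Compound 4 is therefore expected at 16000 nM, within 8000 nM to 32000 nM.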

Compound 4, half-maximal inhibitory concentration: 20200 nM
Beside the measured number, compound 4's estimate is 1.3-fold (0.10 log units) below it; the measured number falls inside the stated range.
By their numbers in this assay, from the lowest: compounds 1, 3, 2 and 4 (each within the scatter of the next).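

In this assay, among these compounds, the change from phenyl to 4-chlorophenyl gives a 1.2-fold higher number from compound 3 to compound 4 (0.08 log units; within the scatter) and so provides the first reading at this ring, which the earlier step did not touch. Chloro in place of hydrogen at this place therefore leaves the number within the scatter, and the series keeps its level with this added heavy atom. Nothing available explains this result.

Going by these compounds, whether an amine or a carboxylic acid in the same place would move the number beyond the scatter remains open. On these data alone, whether the phenyl can be replaced altogether also remains open.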